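Swapping a hydroxyphenyl for a chlorophenyl in a thiazolidinone

The source may report more compounds than this note shows. Statements on the series, on what has been measured and on what is new or still open speak of the compounds shown alone.

Measured compounds:
compound 1, `O=C1/C(=C\c2ccc(O)cc2)S/C(=N/c2ccccc2)N1Cc1ccncc1`, 18900 nM
compound 2, `O=C1/C(=C\c2ccc(O)c(O)c2)S/C(=N/c2ccccc2)N1Cc1ccncc1`, 12400 nM

Among the compounds with values here, in a functional assay on MCF7 cells (Homo sapiens) for cytotoxicity, read by MTT assay, with a stated time of 48 h (a lower number here means a stronger inhibitor, a higher number a weaker inhibitor), compound 1 gives the highest number of the two; its only neighbour is compound 2, and the step of a 1.5-fold lower number from compound 1 to compound 2 (0.18 log units; within the scatter) falls within the scatter. Compound 3, `O=C1/C(=C\c2cccc(Cl)c2)S/C(=N/c2ccccc2)N1Cc1ccncc1`, has not been measured. It differs from compound 1 by 3-chlorophenyl in place of 4-hydroxyphenyl on a double-bonded chain carbon bound to a double-bonded ring carbon. Within the data shown here, no measured step touches this part of the shared core, and the one step known is within the scatter, so no change beyond the scatter is expected. Compound 3 is estimated at 22000 nM, between 7000 nM and 70000 nM, a step of a 1.2-fold higher number from compound 1 to compound 3 (0.07 log units; within the scatter).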

Compound 3, half-maximal inhibitory concentration: 29800 nM
The estimate for compound 3 lay 1.4-fold (0.13 log units) below the measured number; the range from low to high includes it.
By their numbers in this assay, from the lowest: compounds 2, 1 and 3 (each within the scatter of the next, the first and the last beyond it).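

In this assay, within the data shown here, this position, which no earlier step touched, takes 3-chlorophenyl in place of 4-hydroxyphenyl with a 1.6-fold higher number from compound 1 to compound 3 (0.20 log units; within the scatter) and so shows no change beyond the scatter, although the entering group has no hydrogen-bond donor or acceptor. Among these compounds, replacing 3,4-dihydroxyphenyl gives the first step beyond the scatter, a modest one, with a 2.4-fold higher number from compound 2 to compound 3 (0.38 log units; beyond the scatter) as its size. No measurement at hand explains either step.

The compounds shown leave open how 4-chlorophenyl would compare with 3-chlorophenyl at this position. They also leave open whether an aminophenyl or a carboxyphenyl group would stay within the scatter of compound 1.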